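Pyrazolyl removal from compound 1: expected maximal response

The source may report more compounds than this note shows. Statements on the series, on what has been measured and on what is new or still open speak of the compounds shown alone.

Three compounds have been run in a functional assay on CHO cells for agonist activity at Alpha-1A adrenergic receptor (Homo sapiens), read by FLIPR and calcium flux; a lower number here means a smaller maximal response, a higher number a larger maximal response. Compound 1 `c1cc(-c2ccn[nH]2)c2c(c1)C(c1ncc[nH]1)CC2` gives 83%, the second highest of the three numbers. The nearest to it, compound 3 `CCS(=O)(=O)Nc1cccc(Cc2c[nH]cn2)c1`, gives 96%, higher than compound 1 by a gap beyond the usual scatter. The furthest, compound 2 `Cc1c(OCC2=NCCN2)ccc(Cl)c1NS(C)(=O)=O`, gives 60%, lower than compound 1 by a larger gap, also beyond the scatter. No two of these compounds differ in a single place, so no measured step is available to anchor a prediction.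

Compound 4 `c1ccc2c(c1)CCC2c1ncc[nH]1` is the next to be measured in this assay. It differs from compound 1 in one place: hydrogen in place of 1H-pyrazol-5-yl on an aromatic carbon. Everything else in compound 1 stays as it is.

Among the compounds with values here, with no measured step to lean on, the expectation is a moderate fall in maximal response, beyond the scatter, estimated as a number 15 percentage points lower from compound 1 to compound 4 (beyond the scatter). Compound 4 is accordingly expected to reach about 68% in this assay, with an estimated range from 40% to 95%.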

Compound 4, largest response reached (Emax), in percent of the reference or control that the assay uses: 54%
For compound 4 the middle estimate is 14 percentage points above the measured one; the range from low to high includes it.
By their numbers in this assay, from the lowest: compounds 4 and 2 (each within the scatter of the next); then compound 1; then compound 3.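

In this assay, within the data shown here, the exchange of 1H-pyrazol-5-yl for hydrogen on the aromatic carbon gives a number 29 percentage points lower from compound 1 to compound 4 (beyond the scatter) and is the first single-place step. It shows that maximal response at this position depends on the substituent, while the core of compound 4 without the 1H-pyrazol-5-yl still gives 54% as a clear agonist response. Nothing shown explains the size of this step.

Going by these compounds, with only hydrogen and 1H-pyrazol-5-yl compared at this carbon, it remains open whether the higher response needs a five-membered aromatic ring with two hetero atoms or would follow from any substituent there. A methyl group, a phenyl ring or an amine on the same carbon would separate these readings.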